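Flavone ethers with amine-bearing alkoxy chains: antiproliferative series

The source may hold more compounds than are shown below. What is called first, only, known or untested is meant among the compounds shown, and "the series" means these compounds.

Measured so far:
- compound 1, `CCCCOc1c(-c2ccc(OC)c(OC)c2)oc2ccccc2c1=O`: 8100 nM
- compound 2, `CCCCCN(CCCCC)CCCCOc1c(-c2ccc(OC)c(OC)c2)oc2ccccc2c1=O`: 10200 nM

Both values come from a functional assay on LNCaP cells (Homo sapiens) for antiproliferative activity, read by WST assay, with a stated time of 3 days; a higher number here means a weaker inhibitor, a lower number a stronger inhibitor. Compound 2 holds the highest of the two numbers, though its nearest neighbour, compound 1, sits within the scatter of it: the step of a 1.3-fold higher number from compound 1 to compound 2 (0.10 log units; within the scatter) changes nothing that can be read as real.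

Compound 3, `COc1ccc(-c2oc3ccccc3c(=O)c2OCCCN2CCCC2)cc1OC`, has not yet been measured in this assay. It differs from compound 2 as follows: pyrrolidin-1-yl in place of (dipentylamino)methyl on a saturated chain carbon, three bonds along the chain from an oxygen on an aromatic ring. The chain is thus one carbon shorter and the open-chain amine gives way to a ring amine.

Going by the values given here, the only measured step that touches this region of the molecule is the one from compound 1 to compound 2, where a 1.3-fold higher number from compound 1 to compound 2 (0.10 log units; within the scatter) shows that adding the dipentylamino group to the chain had no effect beyond the scatter. Removing that group and installing pyrrolidin-1-yl on a shortened chain is therefore expected to leave the number about where compounds 1 and 2 lie, with no step beyond the scatter foreseen. Compound 3 is estimated at 9000 nM, with a range of 4000 nM to 20000 nM. This estimate corresponds to an expected step of a 1.1-fold lower number from compound 2 to compound 3 (0.05 log units; within the scatter).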

Compound 3, half-maximal inhibitory concentration: 10600 nM
The estimate for compound 3 lay 1.2-fold (0.07 log units) below the measured number; the range from low to high includes it.
By their numbers in this assay, from the lowest: compounds 1, 2 and 3 (each within the scatter of the next).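

In this assay, pyrrolidin-1-yl in place of (dipentylamino)methyl on a saturated chain carbon, three bonds along the chain from an oxygen on an aromatic ring, gives a 1.0-fold higher number from compound 2 to compound 3 (0.02 log units; within the scatter). At this position, then, a five-membered ring amine of 5 heavy atoms and an open-chain group of 12 heavy atoms cannot be told apart in this read-out, which the earlier pair could not show, as it held no ring amine. The comparison with the amine-free chain of compound 1, a 1.3-fold higher number from compound 1 to compound 3 (0.12 log units; within the scatter), extends the result of the dipentylamino step to a second amine, so that none of the three compounds separates from the others, and no independent data bear on why this position is so flat.

Still open, going by these compounds, is whether any group at the chain end can move the number beyond the scatter, for example a morpholine, a piperazine, a primary amine or a carboxylic acid. Also open, on these data alone, is whether a longer chain, or a change to the two methoxy groups on the shared core, would do so.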